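Notes on compound 4: side-chain exchange on the shared core

A few compounds are considered here, and "the series" means these few. Any claim that something is new, unique, unknown or untested is made for them only; others in the source may bear on it.

Measured so far in a functional assay on NCI-H1650 cells (Homo sapiens) for cytotoxicity, read by MTT assay, with a stated time of 48 h; a higher number here means a weaker inhibitor, a lower number a stronger inhibitor:
compound 1 `CN(C)CCNc1ccnc2cc(OCc3ccc(F)cc3)ccc12` gives 780 nM
compound 2 `CN(C)CCNc1ccnc2cc(OCc3ccccc3)ccc12` gives 1620 nM
compound 3 `CCOc1ccc2c(Cl)ccnc2c1` gives 3340 nM

Compound 3 stands at the highest of the three numbers; compound 2 is nearest and compound 1 furthest, both gaps beyond the scatter.

Compound 4 `CCOc1ccc2c(NCCN(C)C)ccnc2c1` differs from compound 3 by (2-(dimethylamino)ethyl)amino in place of chloro on an aromatic carbon. Within the data shown here, the only measured step, a 2.1-fold higher number from compound 1 to compound 2 (0.32 log units; beyond the scatter), concerns the benzyloxy part and leaves the group exchanged here untouched, so no measured pair isolates the chloro-to-amine exchange. What the values show is that compounds 1 and 2, which both carry the entering side chain, sit below compound 3, which lacks it; but those pairs also differ in the other substituent on the shared core, so this is not a clean comparison.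

On that basis a modest downward step is expected, a 1.7-fold lower number from compound 3 to compound 4 (0.22 log units; within the scatter), with wide uncertainty. Compound 4 is estimated to give 2000 nM in this assay, expected to fall between 700 nM and 6000 nM.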

Compound 4, half-maximal inhibitory concentration: 3490 nM
Estimate against measurement, compound 4: 1.7-fold (0.24 log units) below; low and high end bracket the measured number.
By their numbers in this assay, from the lowest: compound 1; then compound 2; then compounds 3 and 4 (each within the scatter of the next).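

In this assay, (2-(dimethylamino)ethyl)amino in place of chloro, on the aromatic carbon opposite the ring nitrogen, gives a 1.0-fold higher number from compound 3 to compound 4 (0.02 log units; within the scatter); with the ethoxy group held, the two compounds cannot be told apart, so this exchange has no measurable effect here. With the side chain held, the steps that lie beyond the scatter come from the other substituent on the shared core: a 2.2-fold higher number from compound 2 to compound 4 (0.33 log units; beyond the scatter) for methyl in place of phenyl, and a 4.5-fold higher number from compound 1 to compound 4 (0.65 log units; beyond the scatter) for methyl in place of 4-fluorophenyl, both modest. No measurement shown accounts for these steps.

From the compounds shown here alone, it remains open whether chloro and the side chain would also stay level on a core carrying benzyloxy. Also open, going by these compounds, is how a longer chain in the side chain, or a morpholine in place of dimethylamino, would read.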